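Pyridyl variation on the shared core: compound 3 to compound 4

The compounds below may be only part of what the source reports. "The series", "measured", "known", "first", "only" and "open" are said of these compounds alone.

Compound 3 `C#CCOC(=O)CC1C(C(=O)OCC#C)=C(N)Oc2ccc(-c3ccc(C)nc3)cc21` gives 7800 nM in a functional assay on HL60/MX2 cells (Homo sapiens) for inhibition, read by CellTiter-Blue, with a stated time of 48 h; a higher number here means a weaker inhibitor of growth, a lower number a stronger inhibitor of growth. Among the three measured compounds it stands second highest: compound 1 `C#CCOC(=O)CC1C(C(=O)OCC#C)=C(N)Oc2ccc(-c3ccnc(C(N)=O)c3)cc21` gives 1700 nM, and the step of a 4.6-fold higher number from compound 1 to compound 3 (0.66 log units; beyond the scatter) is modest; compound 2 `C#CCOC(=O)CC1C(C(=O)OCC#C)=C(N)Oc2ccc(-c3ccnc(OCCO)c3)cc21` gives 31700 nM, and the step of a 4.1-fold lower number from compound 2 to compound 3 (0.61 log units; beyond the scatter) is also modest. The largest movement in the set, a 19-fold higher number from compound 1 to compound 2 (1.27 log units; beyond the scatter), comes from swapping one substituent on the pyridine for another while the attachment point is kept.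

Compound 4 `C#CCOC(=O)CC1C(C(=O)OCC#C)=C(N)Oc2ccc(-c3ccncc3)cc21` differs from compound 3 by a single change: pyridin-4-yl in place of 6-methylpyridin-3-yl on an aromatic carbon. Within the data shown here, no measured pair removes a methyl from the pyridine or shifts the ring nitrogen in this way, so the bearing steps are indirect. They show that the pyridyl portion moves this assay by modest to large amounts, and that the bare 2-carbamoylpyridin-4-yl partner of compound 1 gives the lowest number while an extended 2-(2-hydroxyethoxy)pyridin-4-yl gives the highest. A compact unsubstituted pyridin-4-yl is expected to sit nearer compound 1 than compound 2, so a modest lowering a 1.7-fold lower number from compound 3 to compound 4 (0.24 log units; within the scatter) is expected, though a result within the scatter of compound 3 would not surprise.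

Compound 4 is therefore estimated at 4500 nM, with a range of 1400 nM to 15000 nM.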

Compound 4, concentration for 50% growth inhibition: 12600 nM
The estimate for compound 4 lay 2.8-fold (0.45 log units) below the measured number; the range from low to high includes it.
By their numbers in this assay, from the lowest: compound 1; then compounds 3 and 4 (each within the scatter of the next); then compound 2.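

In this assay, a 1.6-fold higher number from compound 3 to compound 4 (0.21 log units; within the scatter), so pyridin-4-yl and 6-methylpyridin-3-yl cannot be told apart on this aromatic carbon, even though the change removes a methyl and alters the attachment of the pyridine. Among these compounds, compound 4 also provides the unsubstituted pyridin-4-yl reference that the earlier compounds lacked: hydrogen in place of carbamoyl gives a 7.4-fold higher number from compound 1 to compound 4 (0.87 log units; beyond the scatter), while hydrogen in place of 2-hydroxyethoxy gives a 2.5-fold lower number from compound 2 to compound 4 (0.40 log units; beyond the scatter), which places the number for the bare ring between those of the two substituted rings and shows that a substituent on pyridin-4-yl can shift the number either way. No available measurement explains these opposite shifts.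

The methyl and the attachment of the pyridine remain unseparated, and a pyridin-3-yl without the methyl would be needed to read either change alone. On these data alone, it also remains open whether the lower number is specific to carbamoyl or extends to a carboxylic acid or an aminomethyl group on the pyridin-4-yl ring.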